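Swapping a Methoxyethyl Tail for a Pyridylmethyl Tail

This account rests on a few compounds, and the source may have more. Where it says the series, first, only, none or still open, it means among the compounds named here.

Of the compounds shown here, three built on a shared core have been tested in an ADME assay on cells (Homo sapiens) for cytotoxicity, read by polymerase chain reaction, with a stated time of 3 days; a higher number here means that more compound is tolerated, a lower number that less compound is tolerated. Compound 1, `Nc1nc(Cl)c(-c2cccs2)c(N[C@@H]2C[C@H](CO)[C@@H](O)[C@H]2O)n1`, reaches only a limit of the assay, > 25000 nM. Compound 2, `Nc1nc(Cl)c(-c2nc3ccccc3o2)c(N[C@@H]2C[C@H](CO)[C@@H](O)[C@H]2O)n1`, gives 12000 nM. Compound 3, `COCCNc1nc(C)c(-c2nc3ccccc3s2)c(N[C@@H]2C[C@H](CO)[C@@H](O)[C@H]2O)n1`, gives 21000 nM. Compound 3 therefore holds the highest of the two actual numbers, but compound 2 sits within the usual scatter of it, so no order between the two can be read from these figures.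

Going by the values given here, only one step between compounds that differ in a single place has been measured: an at least 2.0-fold lower number from compound 1 to compound 2 (0.31 log units; beyond the scatter). Its size is bounded by the limit of > 25000 nM in this assay, at which 1 of the 3 values shown sits, so only a lower bound on that change is known.

Compound 4, `Cc1nc(NCc2ccccn2)nc(N[C@@H]2C[C@H](CO)[C@@H](O)[C@H]2O)c1-c1nc2ccccc2s1`, differs from compound 3 by pyridin-2-yl in place of methoxymethyl on a saturated chain carbon bound to a nitrogen on an aromatic ring. Among the compounds with values here, this change sits on the amine side chain, a place that the one measured step did not touch, since that step concerned the aromatic substituent. No measured comparison therefore bears directly on the new change, and the two available numbers lie within scatter of each other, leaving no trend to extend. The expectation for this assay is a step of a 1.4-fold lower number from compound 3 to compound 4 (0.15 log units; within the scatter), nothing beyond the scatter. For compound 4 the estimated value is 15000 nM, with a likely range from 6000 nM to 40000 nM.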

Compound 4, half-maximal cytotoxic concentration: 13000 nM
For compound 4 the middle estimate is 1.2-fold (0.06 log units) above the measured one; the measured number falls inside the stated range.
By their numbers in this assay, from the lowest: compounds 2, 4 and 3 (each within the scatter of the next). At a limit, above all of these: compound 1.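

Going by these compounds alone, this is the first measured change on the saturated chain carbon bound to a nitrogen on an aromatic ring; the earlier step concerned a different part of the molecule. In this assay, pyridin-2-yl in place of methoxymethyl gives a 1.6-fold lower number from compound 3 to compound 4 (0.21 log units; within the scatter), so bringing in a six-membered aromatic ring where the leaving group had no ring produces no difference that can be told from repeat measurements. This single pair therefore shows that this position can carry the larger pyridin-2-yl group with no step beyond the scatter, though one pair sets no trend.

Going by these compounds, it remains open whether a plain phenyl ring, a longer chain, or a chain ending in an amine or a carboxylic acid would stay within the scatter at this position, or whether any of them would shift the tolerated concentration clearly. Compound 1 stands at a limit and not at a number, so the one step beyond the scatter, the change on the aromatic carbon, stays bounded on one side only: the limit of > 25000 nM in this assay, at which 1 of the 4 values shown sits.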